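Trifluoromethyl on the Phenyl Ring of a Succinimide Amide

The source may hold more compounds than are shown below. What is called first, only, known or untested is meant among the compounds shown, and "the series" means these compounds.

Compound 1 `CC(C(=O)N1CCN(c2ccccc2)CC1)N1C(=O)CCC1=O`: 165 mg/kg
Compound 2 `CC(C(=O)N1CCN(c2ccc(F)cc2)CC1)N1C(=O)CCC1=O`: 130 mg/kg

In a functional assay on the whole organism (strain Swiss) with Mus musculus as the target, in the maximal electroshock model, with a stated time of 0.25 h (a lower number here means that less compound is needed, a higher number that more compound is needed for the effect), compound 1 gives 165 mg/kg, the highest of the two numbers recorded; the nearest is compound 2, with 130 mg/kg. Within the data shown here, the one measured step, a 1.3-fold lower number from compound 1 to compound 2 (0.10 log units; within the scatter), is within the scatter. Compound 3 `CC(C(=O)N1CCN(c2ccccc2C(F)(F)F)CC1)N1C(=O)CCC1=O` differs from compound 1 by trifluoromethyl in place of hydrogen on an aromatic carbon, on an aromatic carbon of the six-membered ring of carbon only, ortho to a large group. Among the measured compounds shown here, no measured step bears directly on this change; the only comparison available, from compound 1 to compound 2, was within the scatter. Compound 3 is therefore expected at 150 mg/kg (range 75 mg/kg to 300 mg/kg), a change of a 1.1-fold lower number from compound 1 to compound 3 (0.04 log units; within the scatter) that is expected to stay within the scatter.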

Compound 3, dose for half-maximal effect: 75.5 mg/kg
Compound 3: middle estimate off by 2.0-fold (0.30 log units), on the high side; low and high end bracket the measured number.
By their numbers in this assay, from the lowest: compounds 3, 2 and 1 (each within the scatter of the next, the first and the last beyond it).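

With trifluoromethyl on an aromatic carbon, ortho to a large group, the result is a 2.2-fold lower number from compound 1 to compound 3 (0.34 log units; beyond the scatter) in this assay. Of the two single changes to the ring, only this one goes beyond the scatter; the fluoro change gave a 1.3-fold lower number from compound 1 to compound 2 (0.10 log units; within the scatter). No measurement shown here accounts for the lower number.

From the compounds shown here alone, whether the step belongs to trifluoromethyl or to this place on the ring remains open. A chloro or methyl group on the same carbon, and trifluoromethyl on other carbons of the ring, would separate the two.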